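The compounds below may be only part of what the source reports. "The series", "measured", "known", "first", "only" and "open" are said of these compounds alone.

Compound 3 `CN(C)c1ccc(C2C(C#N)=C(N)OC(c3c[nH]c4ccccc34)=C2C#N)cc1` gives 18.5% in a functional assay, tested at 100 ug/mL (a lower number here means a weaker effect, a higher number a stronger effect of the compound at the concentration tested), the middle of three numbers that all lie within the usual scatter of one another. Compound 1 `N#CC1=C(N)OC(c2c[nH]c3ccccc23)=C(C#N)C1c1ccccc1` gives 19.3% in this assay, and compound 2 `N#CC1=C(N)OC(c2c[nH]c3ccccc23)=C(C#N)C1c1ccc(F)cc1` gives 16.2%. Compound 4 `Cc1ccc(C2C(C#N)=C(N)OC(c3c[nH]c4ccccc34)=C2C#N)cc1` differs from compound 3 in one place: methyl in place of dimethylamino on an aromatic carbon. Two measured steps change the group on the same aromatic carbon: a number 0.8 percentage points lower from compound 1 to compound 3 (within the scatter) and a number 2.3 percentage points higher from compound 2 to compound 3 (within the scatter), and the third step, a number 3.1 percentage points lower from compound 1 to compound 2 (within the scatter), also stayed within the scatter. Swapping groups at this position has so far left the read-out where it was, so no step beyond the scatter is expected for a number 0.5 percentage points lower from compound 3 to compound 4 (within the scatter). Compound 4 is therefore estimated at 18%, with a range from 11% to 25% in this assay.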

Compound 4, a percentage reported as activity, at one concentration (the size of the read-out at that concentration, not a potency): 5.5%
The estimate for compound 4 lay 12.5 percentage points above the measured number, outside the stated range (below it).
By their numbers in this assay, from the lowest: compound 4; then compounds 2, 3 and 1 (each within the scatter of the next).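

Swapping groups at this aromatic carbon does matter after all: in this assay the change to methyl moves the read-out beyond the scatter against every earlier group (a number 13 percentage points lower from compound 3 to compound 4 (beyond the scatter) and a number 10.7 percentage points lower from compound 2 to compound 4 (beyond the scatter) and a number 13.8 percentage points lower from compound 1 to compound 4 (beyond the scatter)). Hydrogen, fluoro and dimethylamino remain within the scatter of one another, so among these four groups methyl alone stands apart.

From the compounds shown here alone, whether an ethyl or a methoxy group here would fall with methyl or sit with the other three remains open. Nothing available explains why methyl differs.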